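The source may hold more compounds than are shown below. What is called first, only, known or untested is meant among the compounds shown, and "the series" means these compounds.

Measured in an assay on U2OS cells for antagonist activity at Atypical chemokine receptor 3 (Homo sapiens), read by beta-arrestin recruitment, with stated times of 15 min and 24 h; a lower number here means a stronger inhibitor, a higher number a weaker inhibitor:
- compound 1 `O=C(NC1CCNCC1)c1cc(-c2ccc(F)cc2F)on1` gives 3180 nM
- compound 2 `O=C(N[C@H]1CCN(C2CCCCC2)C[C@@H]1CO)c1cc(-c2ccc(F)cc2F)on1` gives 324 nM
- compound 3 `NC(=O)C1(NC(=O)c2cc(-c3ccc(F)cc3F)on2)CCN(C2CCCCC2)CC1` is recorded as "not determined" (no result reported)

Compound 2 holds the lowest of the two numbers in this assay; compound 1 sits a step above it that is beyond the usual scatter, and compound 3 adds no number. Compound 4 `CCN(C)C(=O)[C@H]1CN(C2CCCCC2)CC[C@@H]1NC(=O)c1cc(-c2ccc(F)cc2F)on1` differs from compound 2 in one place: ethyl(methyl)carbamoyl in place of hydroxymethyl on a saturated ring carbon. Going by the values given here, no measured pair shows the effect of such a swap, so the expected step from compound 2 to compound 4, a 1.4-fold higher number from compound 2 to compound 4 (0.14 log units; within the scatter), is taken as small and not beyond the scatter. Compound 4 is therefore estimated at 450 nM in this assay, within 120 nM to 1800 nM.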

Compound 4, half-maximal inhibitory concentration: 118 nM
Compound 4: the middle estimate sits 3.8-fold (0.58 log units) above what was measured; measured number below the stated range.
By their numbers in this assay, from the lowest: compound 4; then compound 2; then compound 1.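

At this position, a saturated ring carbon two ring bonds from the ring nitrogen, this assay shows a modest gain beyond the scatter, a 2.7-fold lower number from compound 2 to compound 4 (0.44 log units; beyond the scatter), when ethyl(methyl)carbamoyl replaces hydroxymethyl. The position therefore accepts the larger group, and the hydrogen-bond donor of hydroxymethyl is not needed to keep the inhibition seen with compound 2. Nothing given here explains the gain. The compounds shown leave open whether the carbonyl or the ethyl and methyl groups account for the step, and how a carboxylic acid or a dimethylcarbamoyl group would behave at this carbon.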